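A few compounds are considered here, and "the series" means these few. Any claim that something is new, unique, unknown or untested is made for them only; others in the source may bear on it.

Measured so far in a functional assay (plasma) with Oryctolagus cuniculus as the target; a higher number here means a weaker inhibitor, a lower number a stronger inhibitor:
- Compound 1 `Cc1nc2cnccc2n1CC1CCN(C(=O)CC(C)c2ccccc2)CC1` gives 12 nM
- Compound 2 `Cc1nc2cnccc2n1CC1CCN(C(=O)CC(C)(C)c2ccccc2)CC1` gives 6.7 nM
- Compound 3 `Cc1nc2cnccc2n1CC1CCN(C(=O)CC(C)(O)c2ccccc2)CC1` gives 6.9 nM

The value of compound 1 lies within the scatter of both others. Compound 4 `Cc1nc2cnccc2n1CC1CCN(C(=O)N[C@H](C)c2ccccc2)CC1` carries (1-phenylethyl)amino in place of 2-phenylpropyl on a carbonyl carbon. Within the data shown here, no measured step covers this exchange. The nearest evidence comes from single changes on the chain of compound 1, namely a 1.8-fold lower number from compound 1 to compound 2 (0.25 log units; within the scatter) and a 1.7-fold lower number from compound 1 to compound 3 (0.24 log units; within the scatter) and neither leaves the scatter. A step beyond the scatter is therefore not expected in either direction, although this exchange is larger, so the range stays wide. The expected change is a 1.2-fold lower number from compound 1 to compound 4 (0.08 log units; within the scatter) and no more. For compound 4 the estimate is 10 nM with an expected range from 3 nM to 35 nM in this account.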

Compound 4, half-maximal inhibitory concentration: 13 nM
Beside the measured number, compound 4's estimate is 1.3-fold (0.11 log units) below it, and the stated range covers the measured number.
By their numbers in this assay, from the lowest: compounds 2, 3, 1 and 4 (each within the scatter of the next).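

In this assay, replacing 2-phenylpropyl with (1-phenylethyl)amino on a carbonyl carbon gives a 1.1-fold higher number from compound 1 to compound 4 (0.03 log units; within the scatter). The earlier compounds shown here changed only one substituent on the chain, whereas compound 4 shows that this position tolerates exchange of the whole group, including the entry of a hydrogen-bond donor and a defined stereocentre, without leaving the scatter. No available evidence accounts for this result. Going by these compounds, it remains open whether the opposite stereocentre of (1-phenylethyl)amino, or a longer chain such as (3-phenylpropyl)amino on the same carbonyl carbon, would also stay within the scatter.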